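This account rests on a few compounds, and the source may have more. Where it says the series, first, only, none or still open, it means among the compounds named here.

Measured so far in an assay on isolated protein for inhibition of mitogen-activated protein kinase kinase kinase 6 (Homo sapiens); a lower number here means a stronger inhibitor, a higher number a weaker inhibitor:
compound 1 `CC(C)n1cnnc1-c1cccc(NC(=O)Nc2ccccn2)n1`, 1090 nM
compound 2 `CC(C)n1cnnc1-c1cccc(NC(=O)Nc2ncc3[nH]cnc3n2)n1`, 742 nM

Compound 2 holds the lower of the two numbers, yet its gap to compound 1 is within the scatter. Compound 3 `CC(C)n1cnnc1-c1cccc(NC(=O)Nc2cc3ccccn3n2)n1` is still unmeasured; it differs from compound 2 by a group of 9 heavy atoms (7 carbon, 2 nitrogen; one five-membered aromatic ring with 2 hetero atoms, one six-membered aromatic ring with 1 hetero atom) in place of a group of 9 heavy atoms (5 carbon, 4 nitrogen; one five-membered aromatic ring with 2 hetero atoms, one six-membered aromatic ring with 2 hetero atoms), on an amide-type nitrogen. For the measured compounds named here, the only measured step at this same position, a 1.5-fold lower number from compound 1 to compound 2 (0.17 log units; within the scatter), stayed within the scatter, so swapping the group on the amide-type nitrogen has not yet moved the number in this assay beyond noise. Accordingly no step beyond the scatter is expected for compound 3, the estimated shift being a 1.1-fold higher number from compound 2 to compound 3 (0.06 log units; within the scatter). Compound 3 is expected to give 850 nM, within a range of 350 nM to 2100 nM.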

Compound 3, half-maximal inhibitory concentration: 4990 nM
For compound 3 the middle estimate is 5.9-fold (0.77 log units) below the measured one; measured number outside the range, above it.
By their numbers in this assay, from the lowest: compounds 2 and 1 (each within the scatter of the next); then compound 3.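

In this assay the group on the amide-type nitrogen does move the number: a 6.7-fold higher number from compound 2 to compound 3 (0.83 log units; beyond the scatter) and a 4.6-fold higher number from compound 1 to compound 3 (0.66 log units; beyond the scatter) both lie beyond the scatter, unlike the earlier step at this position. Both groups in the step from compound 2 hold 9 heavy atoms, so heavy-atom count alone does not set the number here. No available data explain the rise.

Still open, on these data alone, is whether the change in ring nitrogens or the lost hydrogen-bond donor matters more. Also open, as far as these compounds go, is how a plain phenyl or a methyl would fare on this nitrogen.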